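The compounds below may be only part of what the source reports. "The series", "measured", "known", "first", "only" and "open" are said of these compounds alone.

Compound 1 `C/C=C\C=C\[C@](C)(O)C/C=C/[C@H]1[C@H](O)CC(=O)[C@@H]1CC/C=C\CCC(=O)OC`: 0.306 mg/kg
Compound 2 `C/C=C(C)/C=C/[C@](C)(O)C/C=C/[C@H]1[C@H](O)CC(=O)[C@@H]1CC/C=C\CCC(=O)OC`: 0.185 mg/kg

For the measured compounds named here, in a functional assay on the whole organism with Rattus norvegicus as the target (on this read-out lower numbers stand for an effect already at smaller amounts and higher numbers for an effect only at larger amounts of compound), only these two compounds have numbers so far, and they cannot be ranked. Going by the values given here, the step separating them (a 1.7-fold lower number from compound 1 to compound 2 (0.22 log units; within the scatter)) stays within the usual scatter, so compound 2 stands level with its only measured neighbour.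

The unmeasured compound 3 `C=C(C)/C=C/[C@](C)(O)C/C=C/[C@H]1[C@H](O)CC(=O)[C@@H]1CC/C=C\CCC(=O)OC` differs from compound 2 in one group. It carries 1-methylethenyl in place of 1-methylprop-1-en-1-yl on a double-bonded chain carbon bound to a double-bonded chain carbon.

Among the compounds with values here, only one measured step bears on this change, the swap of prop-1-en-1-yl for 1-methylprop-1-en-1-yl at that same place (a 1.7-fold lower number from compound 1 to compound 2 (0.22 log units; within the scatter)). A single step is thin evidence, but it gives no sign that changes at this place move the number much. In this assay no shift beyond the scatter is therefore expected, in either direction. The expected step is small (a 1.4-fold higher number from compound 2 to compound 3 (0.13 log units; within the scatter)). For compound 3 the estimated value is 0.25 mg/kg, with an expected range from 0.1 mg/kg to 0.6 mg/kg.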

Compound 3, dose for half-maximal effect: 0.42 mg/kg
Compound 3: the middle estimate sits 1.7-fold (0.23 log units) below what was measured; low and high end bracket the measured number.
By their numbers in this assay, from the lowest: compounds 2, 1 and 3 (each within the scatter of the next, the first and the last beyond it).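

In this assay, this place on a double-bonded chain carbon bound to a double-bonded chain carbon now shows its first change beyond the usual scatter: 1-methylethenyl in place of 1-methylprop-1-en-1-yl gives a modest step (a 2.3-fold higher number from compound 2 to compound 3 (0.36 log units; beyond the scatter)), so the position is not wholly indifferent to what sits there. The picture stays narrow, however, since 1-methylethenyl in place of prop-1-en-1-yl stays within the scatter (a 1.4-fold higher number from compound 1 to compound 3 (0.14 log units; within the scatter)), which leaves compound 1 level with both of the others and only compound 2 and compound 3 apart. Nothing available explains why the number moves with this change.

Going by these compounds, all three groups at this place are open carbon chains with one double bond, so it remains open how a phenyl ring, a saturated ethyl chain or an amine would behave there. On these data alone, it also remains open whether a step this modest would appear again if the same swap were made with other parts of the shared core changed.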